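Before the measurement: compound 3 in a chlorophenol urea series

The source may hold more compounds than are shown below. What is called first, only, known or untested is meant among the compounds shown, and "the series" means these compounds.

Two compounds have been measured in a functional assay on NCI/ADR-RES cells (Homo sapiens) for inhibition, read by sulforhodamine B assay, with a stated time of 48 h, tested at 0.1 uM; on this read-out lower numbers stand for a stronger effect and higher numbers for a weaker effect at the one concentration tested:
- compound 1 `O=C(Nc1cccc(-n2cc(-c3ccncc3)c(-c3cc(O)cc(Cl)c3)n2)c1)Nc1ccc(Cl)c(C(F)(F)F)c1` gives 92%
- compound 2 `COc1cc(Cl)cc(-c2nn(-c3cccc(NC(=O)Nc4ccc(Cl)c(C(F)(F)F)c4)c3)cc2-c2ccncc2)c1` gives 69%

Among the compounds with values here, compound 2 stands lowest of the two numbers; its nearest neighbour is compound 1, and the only measured step, a number 23 percentage points lower from compound 1 to compound 2 (beyond the scatter), concerns methyl in place of hydrogen on an oxygen on an aromatic ring. Compound 3 `COc1cc(Cl)cc(-c2nn(-c3cccc(NC(=O)c4cccc(C(F)(F)F)c4)c3)cc2-c2ccncc2)c1` is not yet measured. It differs from compound 2 by 3-(trifluoromethyl)phenyl in place of (4-chloro-3-(trifluoromethyl)phenyl)amino on a carbonyl carbon. Within the data shown here, no measured step bears on this change, so the expectation rests on nothing more than the direction of the structural loss. Compound 3 is expected to give a weaker effect, an estimated step of a number 16 percentage points higher from compound 2 to compound 3 (beyond the scatter). Compound 3 is estimated at 85%, between 60% and 105%.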

Compound 3, a percentage reported as activity, at one concentration (the size of the read-out at that concentration, not a potency): 104%
Compound 3: the middle estimate sits 19 percentage points below what was measured, and the stated range covers the measured number.
By their numbers in this assay, from the lowest: compound 2; then compound 1; then compound 3.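

In this assay, 3-(trifluoromethyl)phenyl in place of (4-chloro-3-(trifluoromethyl)phenyl)amino on the carbonyl carbon gives a number 35 percentage points higher from compound 2 to compound 3 (beyond the scatter), showing that the effect at this concentration depends strongly on what this position carries. The change removes the amino hydrogen-bond donor and the chlorine together, so the two cannot be told apart here. No measurement available here accounts for the step.

Still open, on these data alone, is whether 3-(trifluoromethyl)phenylamino, which keeps the amino nitrogen without the chlorine, or 4-chloro-3-(trifluoromethyl)phenyl, which keeps the chlorine without the amino nitrogen, would retain the effect at this position.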